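A few compounds are considered here, and "the series" means these few. Any claim that something is new, unique, unknown or untested is made for them only; others in the source may bear on it.

Working notes on the series. Three aryl-ketone thiophenes with a piperazine linker have been run in a functional assay on CHO cells with adenosine receptor A1 (Homo sapiens) as the target, read by cAMP accumulation and immunoassay, with a stated time of 6 min, tested at 0.01 uM; on this read-out higher numbers stand for a weaker effect at the one concentration tested and lower numbers for a stronger effect. Compound 1 `CC(C)N1CCN(Cc2csc(N)c2C(=O)c2ccc(Cl)cc2)CC1` gives -1%, compound 2 `Nc1scc(CN2CCN(c3cccc(Cl)c3Cl)CC2)c1C(=O)c1ccc(Cl)cc1` gives 1%, and compound 3 `COc1ccc(N2CCN(Cc3csc(N)c3C(=O)c3ccc(Cl)cc3)CC2)cc1` gives -1.2%. Compound 3 holds the smallest of the three numbers, yet the two steps that end at it are a number 0.2 percentage points lower from compound 1 to compound 3 (within the scatter) and a number 2.2 percentage points lower from compound 2 to compound 3 (within the scatter), and the remaining step is a number 2 percentage points higher from compound 1 to compound 2 (within the scatter), so all three sit within the scatter of one another at this single concentration.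

Compound 4 `Nc1scc(CN2CCN(c3ccccc3C(F)(F)F)CC2)c1C(=O)c1ccc(Cl)cc1` is the next member: 2-(trifluoromethyl)phenyl in place of 4-methoxyphenyl on an amine nitrogen in a ring. Among the compounds with values here, the steps that bear on this are those that exchange the group on the ring nitrogen, namely from compound 1 to compound 2 and from compound 2 to compound 3 ; both were within the scatter, and none of the measured compounds gives a number beyond it. Nothing in these data therefore points to a step in this assay beyond the scatter from compound 3 to compound 4 , and the expected step is a number 1.2 percentage points higher from compound 3 to compound 4 (within the scatter). Compound 4 is estimated at 0%, with a range from -8% to 8%.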

Compound 4, a percentage reported as activity, at one concentration (the size of the read-out at that concentration, not a potency): 0%
For compound 4 middle estimate and measured number coincide at the digits printed, and the stated range covers the measured number.
By their numbers in this assay, from the lowest: compounds 3, 1, 4 and 2 (each within the scatter of the next).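

With 2-(trifluoromethyl)phenyl, the amine nitrogen in a ring now carries a fluorine-bearing group, and in this assay the result is a number 1.2 percentage points higher from compound 3 to compound 4 (within the scatter), a number 1 percentage points lower from compound 2 to compound 4 (within the scatter) and a number 1 percentage points higher from compound 1 to compound 4 (within the scatter). Across isopropyl, 2,3-dichlorophenyl, 4-methoxyphenyl and 2-(trifluoromethyl)phenyl, no exchange at this position gives a step beyond the scatter at the one concentration tested, so the four compounds cannot be told apart on this read-out. No supporting measurement bears on this result.

Because only one concentration is shown, any differences in potency among the four compounds remain open. From the compounds shown here alone, it is also open whether a carboxylic acid, a primary amine or a longer alkyl chain on the same ring nitrogen would give a number beyond the scatter.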